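This account rests on a few compounds, and the source may have more. Where it says the series, first, only, none or still open, it means among the compounds named here.

Compound 1 `O=C(/C(=C\c1ccc(OCc2ccccc2)cc1)SCc1ccc(Cl)cc1)c1ccc(Cl)cc1`: 1000 nM
Compound 2 `Cc1cc(C)cc(/C=C(/SCc2ccc(Cl)cc2)C(=O)c2ccc(Cl)cc2)c1`: 10000 nM
Compound 3 `O=C(/C(=C\c1ccc(O)cc1)SCc1ccc(Cl)cc1)c1ccc(Cl)cc1`: 10000 nM

These three compounds were tested in a functional assay on DU-145 cells (Homo sapiens) for inhibition, read by trypan blue exclusion, with a stated time of 96 h; a lower number here means a stronger inhibitor of growth, a higher number a weaker inhibitor of growth. There, compound 2 stands level with compound 3 at 10000 nM, and compound 1 has the lower number. The next compound, compound 4 `CSc1ccc(/C=C(/SCc2ccc(Cl)cc2)C(=O)c2ccc(Cl)cc2)cc1`, carries methylsulfanyl in place of hydroxy on an aromatic carbon, para to a large group: methylsulfanyl in place of hydroxy on an aromatic carbon.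

Among the measured compounds shown here, no measured step tests methylsulfanyl directly, so the evidence is indirect. For the measured compounds named here, the one large step, a 10-fold higher number from compound 1 to compound 3 (1.00 log units; beyond the scatter), came with hydrogen in place of benzyl on an oxygen on an aromatic ring, and the present change involves no benzyl group. Closer in kind is no change at the digits printed from compound 2 to compound 3 (within the scatter), where 4-hydroxyphenyl replaced 3,5-dimethylphenyl and the number held.

Little movement in this assay is therefore expected, and any shift should stay within the scatter or only just exceed it. The expected step is a 1.7-fold lower number from compound 3 to compound 4 (0.22 log units; within the scatter). For compound 4 the estimated value is 6000 nM, with an expected range of 2000 nM to 15000 nM.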

Compound 4, concentration for 50% growth inhibition: 25000 nM
Compound 4: middle estimate off by 4.2-fold (0.62 log units), on the low side, outside the stated range (above it).
By their numbers in this assay, from the lowest: compound 1; then compounds 2 and 3 (each within the scatter of the next); then compound 4.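

At this aromatic carbon, para to a large group, the change from hydroxy to methylsulfanyl is not silent in this assay: it gives a 2.5-fold higher number from compound 3 to compound 4 (0.40 log units; beyond the scatter) on an otherwise unchanged structure. Against the 3,5-dimethylphenyl of compound 2, 4-hydroxyphenyl had stood level, but 4-(methylsulfanyl)phenyl does not, giving a 2.5-fold higher number from compound 2 to compound 4 (0.40 log units; beyond the scatter) in that place. With a 25-fold higher number from compound 1 to compound 4 (1.40 log units; beyond the scatter) on going from benzyloxy to methylsulfanyl, this carbon now carries three groups whose steps all lie beyond the scatter, with benzyloxy giving the lowest number and methylsulfanyl the highest.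

Nothing measured among these compounds accounts for the step from hydroxy to methylsulfanyl. Going by these compounds, whether an amine or benzylsulfanyl at this carbon would stand nearer to benzyloxy or to methylsulfanyl remains open.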